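Imidazol-1-ylmethyl replacement at the benzylic amine position

A few compounds are considered here, and "the series" means these few. Any claim that something is new, unique, unknown or untested is made for them only; others in the source may bear on it.

Working notes on the series. Compound 1 `CNCCN(C)Cc1ccc(-c2ccnc3ccc(-c4cnc(OC)c(NS(=O)(=O)c5ccc(F)cc5F)c4)cc23)cc1` and compound 2 `COc1ncc(-c2ccc3nccc(-c4ccc(CN5CCCCC5)cc4)c3c2)cc1NS(=O)(=O)c1ccc(F)cc1F` share the same core and differ only at the group on a saturated chain carbon bound to an aromatic carbon. In a functional assay on HCT-116 cells (Homo sapiens) for cytotoxicity, read by MTT assay, with a stated time of 72 h (on this read-out lower numbers stand for stronger inhibition and higher numbers for weaker inhibition), compound 1 gives 51.8 nM, and in this assay compound 2 gives 34.1 nM. The step of a 1.5-fold lower number from compound 1 to compound 2 (0.18 log units; within the scatter) shows that exchanging one amine-type substituent for another at this position leaves the read-out essentially unchanged. Compound 2 has the lower of the two numbers, but the gap to compound 1 is within the scatter, so no order is claimed.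

Compound 3 `COc1ncc(-c2ccc3nccc(-c4ccc(Cn5ccnc5)cc4)c3c2)cc1NS(=O)(=O)c1ccc(F)cc1F` is not yet measured. It differs from compound 2 by 1H-imidazol-1-yl in place of piperidin-1-yl on a saturated chain carbon bound to an aromatic carbon. Within the data shown here, the only step that bears on this position is the one from compound 1 to compound 2, which was within the scatter, so the position appears tolerant of different nitrogen-containing groups. Among the measured compounds shown here, with only one relevant step, the expectation is a change of a 1.5-fold higher number from compound 2 to compound 3 (0.17 log units; within the scatter) in this assay, that is no shift beyond the scatter. For compound 3 the estimated value in this assay is 50 nM, with a range from 15 nM to 170 nM.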

Compound 3, half-maximal inhibitory concentration: 32.6 nM
For compound 3 the middle estimate is 1.5-fold (0.19 log units) above the measured one, within the range that was stated.
By their numbers in this assay, from the lowest: compounds 3, 2 and 1 (each within the scatter of the next).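

Exchanging piperidin-1-yl for 1H-imidazol-1-yl on a saturated chain carbon bound to an aromatic carbon gives, in this assay, a 1.0-fold lower number from compound 2 to compound 3 (0.02 log units; within the scatter) and so replaces a six-membered non-aromatic ring with a five-membered aromatic ring without a shift beyond the scatter. The comparison with the open-chain group gives a 1.6-fold lower number from compound 1 to compound 3 (0.20 log units; within the scatter) and is also within the scatter, so the three groups shown at this place cannot be put in any order in this assay and the tolerance seen earlier now extends to an aromatic ring. Nothing on hand bears on why the read-out stays within the scatter across these groups.

All three groups are attached at this place through a nitrogen, so the compounds shown leave open whether a group attached through another atom, such as a carboxylic acid or a methoxy group, would fit the same picture. Going by these compounds, how a longer chain carrying the piperidin-1-yl or 1H-imidazol-1-yl ring would read in this cell assay also remains open.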